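Three Aryl-Pyridines and a Fourth Still Unmeasured

This account rests on a few compounds, and the source may have more. Where it says the series, first, only, none or still open, it means among the compounds named here.

Three compounds built on a shared core were examined in an assay on isolated protein for inhibition of DNA topoisomerase 1 (Homo sapiens), with a stated time of 30 min, tested at 20 uM; on this read-out higher numbers stand for a stronger effect at the one concentration tested and lower numbers for a weaker effect. Compound 1 `Oc1ccc(-c2cc(-c3ccoc3)cc(-c3ccccc3O)n2)cc1` gives 3.9% in this assay. Compound 2 `Oc1ccc(-c2cc(-c3ccoc3)cc(-c3cccc(O)c3)n2)cc1` gives 1.3% in this assay, and compound 3 `Oc1cccc(-c2cc(-c3cccnc3)cc(-c3ccccc3O)n2)c1` gives 0% in this assay. The difference between the core of compound 1 and the core of compound 3 is not broken down here; the two values simply show that both compounds sit at the low end of the read-out.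

Between compound 1 and compound 2 one change is made: 3-hydroxyphenyl in place of 2-hydroxyphenyl on an aromatic carbon. Among the measured compounds shown here, this change gave a number 2.6 percentage points lower from compound 1 to compound 2 (within the scatter), a step that counts as no step at all.

Compound 4 `Oc1cccc(-c2cc(-c3cccnc3)cc(-c3cccc(O)c3)n2)c1` has not yet been measured in this assay. It stands to compound 3 as compound 2 stands to compound 1: 3-hydroxyphenyl in place of 2-hydroxyphenyl on an aromatic carbon. The two places are not identical, though. In compound 1 the changed group sits meta to a 4-hydroxyphenyl group and meta to a furan-3-yl group, whereas in compound 3 it sits meta to a 3-hydroxyphenyl group and meta to a pyridin-3-yl group, so this is the same kind of change rather than the same change.

For the measured compounds named here, since the one earlier instance of this change gave a number 2.6 percentage points lower from compound 1 to compound 2 (within the scatter) and compound 3 gives 0%, the step from compound 3 to compound 4 is expected to be about a number 1 percentage points higher from compound 3 to compound 4 (within the scatter). Compound 4 is therefore estimated to give about 1% in this assay, most likely between 0% and 8%.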

Compound 4, a percentage reported as inhibition, at one concentration (the size of the read-out at that concentration, not a potency): 1.9%
Beside the measured number, compound 4's estimate is 0.9 percentage points below it; the range from low to high includes it.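

In this assay, putting 3-hydroxyphenyl in place of 2-hydroxyphenyl on the core of compound 3 gave a number 1.9 percentage points higher from compound 3 to compound 4 (within the scatter), so here too the change leaves the read-out where it was. Set beside the earlier instance on the core of compound 1, the two steps do not differ, and in that limited sense the change carries from one core to the other: the same change on two cores in this assay, a number 2.6 percentage points lower (within the scatter) from compound 1 to compound 2 and a number 1.9 percentage points higher (within the scatter) from compound 3 to compound 4, 4.5 percentage points apart, within the scatter of two such steps. Among the compounds shown here, this does not show that the change carries any effect with it, since all four compounds sit at the low end of the read-out and the agreement is between two steps that are each no step at all; two such pairs also say nothing about how the change would behave on a core with a clearly higher number.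

The compounds shown leave open whether anything on this scaffold moves the read-out away from the low end, as every aryl group here is a hydroxyphenyl, furan-3-yl or pyridin-3-yl group. An amine or a carboxylic acid in place of the hydroxyl, or a longer chain carrying either of them, lies outside what these four compounds can speak to.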